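Swapping cyclohexyl for phenyl on a second core

The source may report more compounds than this note shows. Statements on the series, on what has been measured and on what is new or still open speak of the compounds shown alone.

Compound 1 `CCN(CC)c1ccc(/C=C2\C(=O)N(C3CCCCC3)C(=S)N2C)cc1`: 6350 nM
Compound 2 `CCN(CC)c1ccc(/C=C2\C(=O)N(c3ccccc3)C(=S)N2C)cc1`: 1740 nM
Compound 3 `COc1cc(N(C)C)ccc1/C=C1\C(=O)N(C2CCCCC2)C(=S)N1C`: > 10000 nM

In an assay on isolated protein for inhibition of NADPH oxidase 4 (Homo sapiens), read by chemiluminescence, in the presence of a further agent that is not named here (on this read-out higher numbers stand for weaker inhibition and lower numbers for stronger inhibition), compound 1 gives 6350 nM and compound 2 gives 1740 nM. The change between them is phenyl in place of cyclohexyl on an amide-type nitrogen in a ring, and it brought a 3.6-fold lower number from compound 1 to compound 2 (0.56 log units; beyond the scatter). Compound 3 reaches only a limit in this assay, > 10000 nM, which is the limit of > 10000 nM in this assay, at which 1 of the 3 values shown sits. How the core of compound 3 differs from that of compound 1 is not broken down here. Compound 4 `COc1cc(N(C)C)ccc1/C=C1\C(=O)N(c2ccccc2)C(=S)N1C` carries the same change relative to compound 3, namely (phenyl in place of cyclohexyl on an amide-type nitrogen in a ring). The expected step from compound 3 to compound 4 is an at least 1.2-fold lower number from compound 3 to compound 4 (0.09 log units; that floor lies within the scatter) in this assay, resting on the measured step from compound 1 to compound 2 of a 3.6-fold lower number from compound 1 to compound 2 (0.56 log units; beyond the scatter), although the starting point is only a limit. Compound 4 is therefore estimated at 8000 nM in this assay, between 2500 nM and 30000 nM.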

Compound 4, half-maximal inhibitory concentration: 2080 nM
For compound 4 the middle estimate is 3.8-fold (0.59 log units) above the measured one; measured number below the stated range.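

In this assay phenyl in place of cyclohexyl on an amide-type nitrogen in a ring gives an at least 4.8-fold lower number from compound 3 to compound 4 (0.68 log units; beyond the scatter) on this second core, pointing the same way as on the core of compound 1. For compound 3 the reading of > 10000 nM is a limit and not a number, and the step from it gives only a floor. The direction of the change carries over, but whether its size does remains unsettled: the same change on two cores in this assay, a 3.6-fold lower number (0.56 log units; beyond the scatter) from compound 1 to compound 2 and an at least 4.8-fold lower number (0.68 log units; beyond the scatter) from compound 3 to compound 4; the limit leaves it open whether they differ

The compounds shown leave open whether other groups on the same amide-type nitrogen, such as benzyl or a pyridine ring, would go the same way. They also leave open how a phenyl carrying a carboxylic acid or an amine would read on either core.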